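Quinazoline-urea series: nitrophenyl to trifluoromethylphenyl swap

The compounds below may be only part of what the source reports. "The series", "measured", "known", "first", "only" and "open" are said of these compounds alone.

Measured so far:
compound 1 `O=C(Nc1ccc([N+](=O)[O-])cc1)Nc1cccc(CNc2ncnc3ccccc23)c1`: 9420 nM
compound 2 `O=C(Nc1cccc(CNc2ncnc3ccccc23)c1)Nc1cccc(C(F)(F)F)c1`: > 50000 nM
compound 3 `COc1cc2ncnc(NCc3cccc(NC(=O)Nc4ccc([N+](=O)[O-])cc4)c3)c2cc1OC`: 8120 nM

In a functional assay on MGC-803 cells (Homo sapiens) for antiproliferative activity, read by MTT assay (on this read-out lower numbers stand for stronger inhibition and higher numbers for weaker inhibition), compound 1 gives 9420 nM. Compound 2 reaches only a limit of this assay, > 50000 nM. The change between them is 3-(trifluoromethyl)phenyl in place of 4-nitrophenyl on an amide-type nitrogen, and it made an at least 5.3-fold higher number from compound 1 to compound 2 (0.72 log units; beyond the scatter); that step rests on (the limit of > 50000 nM in this assay, at which 1 of the 3 values shown sits). Compound 3 gives 8120 nM in this assay, a number within the scatter of compound 1. The difference between the two cores, that of compound 1 and that of compound 3, is not broken down here.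

Compound 4 `COc1cc2ncnc(NCc3cccc(NC(=O)Nc4cccc(C(F)(F)F)c4)c3)c2cc1OC` is not yet measured. It differs from compound 3 by 3-(trifluoromethyl)phenyl in place of 4-nitrophenyl on an amide-type nitrogen, the same change as from compound 1 to compound 2, on the same place. The expected step is a 5.5-fold higher number from compound 3 to compound 4 (0.74 log units; beyond the scatter), which rests on the earlier step of an at least 5.3-fold higher number from compound 1 to compound 2 (0.72 log units; beyond the scatter). Compound 4 is therefore expected to give about 45000 nM, estimated from 15000 nM to 150000 nM, with a fair chance that this assay reports only a limit.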

Compound 4, half-maximal inhibitory concentration: > 50000 nM
Compound 4: a limit, no number; the forecaster's own chance of this, stated with the estimate: 60%; at least 1.1-fold (0.04 log units) between middle value and limit.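

The change to 3-(trifluoromethyl)phenyl in place of 4-nitrophenyl on an amide-type nitrogen gives an at least 6.1-fold higher number from compound 3 to compound 4 (0.78 log units; beyond the scatter), so on the two cores shown it moves the number the same way. In this assay compound 4 gives > 50000 nM, which is a limit of the assay and not a number. The direction therefore carries from one core to the other, but equal size on the two cores is not shown: the same change on two cores in this assay, an at least 5.3-fold higher number (0.72 log units; beyond the scatter) from compound 1 to compound 2 and an at least 6.1-fold higher number (0.78 log units; beyond the scatter) from compound 3 to compound 4; the limit leaves it open whether they differ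

The compounds shown leave open how a phenyl carrying a nitrile or a carboxylic acid would read on either core. Also open, going by these compounds, is whether an unsubstituted phenyl on the same nitrogen would read closer to 4-nitrophenyl or to 3-(trifluoromethyl)phenyl.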